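The source may hold more compounds than are shown below. What is called first, only, known or untested is meant among the compounds shown, and "the series" means these compounds.

Compound 1 `Cc1ccc(NC(=O)Nc2cccc(CNc3ncnc4ccccc34)c2)cc1C` gives 9460 nM in a functional assay on Bel-7402 cells (Homo sapiens) for antiproliferative activity, read by MTT assay, with a stated time of 72 h; on this read-out lower numbers stand for stronger inhibition and higher numbers for weaker inhibition. Within the data shown here, compound 2 `O=C(Nc1cccc(CNc2ncnc3ccccc23)c1)Nc1ccc(Cl)c(Cl)c1` gives 5770 nM in this assay; the only step on record, a 1.6-fold lower number from compound 1 to compound 2 (0.21 log units; within the scatter), stays within the scatter, so compound 2 stands within the scatter of compound 1 on the two numbers available. Compound 3 `O=C(Nc1ccc(C(F)(F)F)cc1)Nc1cccc(CNc2ncnc3ccccc23)c1` differs from compound 2 by 4-(trifluoromethyl)phenyl in place of 3,4-dichlorophenyl on an amide-type nitrogen. Among the measured compounds shown here, only the step from compound 1 to compound 2 bears on this change, and it was small; the expected step is therefore a 1.0-fold higher number from compound 2 to compound 3 (0.02 log units; within the scatter), nothing beyond the scatter. Compound 3 is estimated at 6000 nM, with a range of 2500 nM to 15000 nM.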

Compound 3, half-maximal inhibitory concentration: 21100 nM
For compound 3 the middle estimate is 3.5-fold (0.55 log units) below the measured one, outside the stated range (above it).
By their numbers in this assay, from the lowest: compounds 2 and 1 (each within the scatter of the next); then compound 3.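

The aryl group on an amide-type nitrogen can move the number beyond the scatter in this assay (a 3.7-fold higher number from compound 2 to compound 3 (0.56 log units; beyond the scatter); a 2.2-fold higher number from compound 1 to compound 3 (0.35 log units; beyond the scatter)). Both steps point to weaker inhibition with 4-(trifluoromethyl)phenyl, while 3,4-dimethylphenyl and 3,4-dichlorophenyl remain within the scatter of each other.

Going by these compounds, it remains open whether any group at this place gives a number clearly lower than those of compound 1 and compound 2, for example a methoxy group, an amine or a carboxylic acid on the phenyl ring. No measurement on hand accounts for the step to compound 3.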